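The compounds below may be only part of what the source reports. "The series", "measured", "known", "first", "only" and "open" are said of these compounds alone.

Compound 1, `Cc1ccc(S(=O)(=O)Cc2ccccc2)cc1C#Cc1cc(Cl)ccc1OCC(=O)O`, is one of three compounds tested in an assay on CHO cells for displacement of a labelled ligand from prostaglandin D2 receptor 2 (Homo sapiens), read by scintillation counting (on this read-out higher numbers stand for weaker inhibition and lower numbers for stronger inhibition), and there it gives 5 nM. Among the three numbers it stands second highest, yet the company it keeps matters: compound 3, `CC(C)c1ccc(S(C)(=O)=O)cc1C#Cc1cc(Cl)ccc1OCC(=O)O`, gives 4.6 nM in this assay, and the gap between compound 1 and compound 3 lies within the usual scatter, so the two cannot be ranked against each other. Compound 2, `O=C(O)COc1ccc(Cl)cc1C#Cc1ccccc1`, gives 108 nM in this assay, and its gap to compound 1 lies well beyond the scatter. Compound 2 carries no sulfonyl group at all, whereas compound 1 and compound 3 each carry one, differently substituted.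

Compound 4, `Cc1ccc(S(=O)(=O)NC(C)(C)C)cc1C#Cc1cc(Cl)ccc1OCC(=O)O`, has not yet been measured. It differs from compound 1 in a single place: (tert-butyl)amino in place of benzyl on a sulfonyl sulfur. Benzyl leaves and (tert-butyl)amino enters on the sulfonyl sulfur.

Since compound 1 and compound 3 sit close together with different groups on that sulfur, the sulfonyl position looks tolerant of variation. Among the compounds with values here, no measured pair isolates this exact change, so the expectation is a modest step, if any, in the direction of a slightly higher number. The expected step of a 1.6-fold higher number from compound 1 to compound 4 (0.20 log units; within the scatter) is judged to stay within or near the scatter. Compound 4 is therefore expected to give 8 nM in this assay, with a range from 2.5 nM to 25 nM.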

Compound 4, inhibition constant: 5 nM
Compound 4: middle estimate off by 1.6-fold (0.20 log units), on the high side; the range from low to high includes it.
By their numbers in this assay, from the lowest: compounds 3, 1 and 4 (each within the scatter of the next); then compound 2.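

Within the data shown here, the earlier compounds offered no pair differing in one place at the sulfonyl sulfur, and this pair is the first to isolate a change there. In this assay, putting (tert-butyl)amino in place of benzyl gives no change at the digits printed from compound 1 to compound 4 (within the scatter) and so leaves the read-out where it was, even though the six-membered aromatic ring of benzyl leaves and a ringless group with a nitrogen and a hydrogen-bond donor enters. For this pair, then, binding in this assay does not depend on keeping benzylsulfonyl, and (tert-butyl)sulfamoyl serves as well, but nothing measured here explains why the two groups read alike.

The compounds shown leave open how far this tolerance extends, for instance to a plain amino group, a morpholine ring or a longer chain ending in a carboxylic acid on the same sulfur. They also leave open whether the amide hydrogen of (tert-butyl)amino matters, which a version carrying an added methyl on that nitrogen would address, and whether the same change would read alike on the core of compound 3.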